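Chain-end variation on the butoxy side chain

This account rests on a few compounds, and the source may have more. Where it says the series, first, only, none or still open, it means among the compounds named here.

The series shares an allyl-acetyl-phenol core carrying an ether chain. Compound 1 is `C=CCc1cc(C(C)=O)c(O)cc1OCCCC#N` and compound 2 is `C=CCc1cc(C(C)=O)c(O)cc1OCCCC`. In an assay on isolated protein for binding affinity to leukotriene B4 receptor 1 (Homo sapiens), tested at 1 uM (a lower number here means less inhibition, a higher number more inhibition at the concentration tested (going by the name of the read-out)), compound 1 gives 6% and compound 2 gives 8%; the two sit level with each other, since the change a number 2 percentage points higher from compound 1 to compound 2 (within the scatter) lies within the scatter. Compound 2 is thus the reference point of the pair, with the unsubstituted chain.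

Compound 3 is `C#CCCCCOc1cc(O)c(C(C)=O)cc1CC=C`. It differs from compound 2 by ethynyl in place of hydrogen on a saturated chain carbon, four bonds along the chain from an oxygen on an aromatic ring. Among the compounds with values here, the only measured step that bears on it is the one from compound 1 to compound 2, also a swap at the far end of the same ether chain, and that step was within the scatter. Nothing in the two measured compounds shows the chain end moving this assay by more than the scatter, so in this assay compound 3 is expected to change by a number 2 percentage points higher from compound 2 to compound 3 (within the scatter), no direction beyond the scatter being indicated. Compound 3 is therefore estimated at 10%, with a range from 0% to 28%.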

Compound 3, a percentage reported as inhibition, at one concentration (the size of the read-out at that concentration, not a potency): 29%
For compound 3 the middle estimate is 19 percentage points below the measured one; measured number above the stated range.
By their numbers in this assay, from the lowest: compounds 1 and 2 (each within the scatter of the next); then compound 3.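

At the far end of the ether chain, ethynyl in place of hydrogen, on a saturated chain carbon four bonds along the chain from an oxygen on an aromatic ring, gives in this assay a number 21 percentage points higher from compound 2 to compound 3 (beyond the scatter), so changes at this chain end can move the read-out beyond the scatter, which compound 1 and compound 2 alone did not show. Propargyl in place of cyano, on a saturated chain carbon three bonds along the chain from an oxygen on an aromatic ring, gives a number 23 percentage points higher from compound 1 to compound 3 (beyond the scatter), so a nitrile and the longer alkyne-ended chain are not interchangeable here, even though each ends in a triple bond. No measurement at hand explains the rise.

The step from compound 2 adds both chain length and a triple bond, and these compounds cannot separate the two, so a saturated hexyl chain and a pent-4-yn-1-yl chain would be the informative neighbours. Also open, going by these compounds, is whether a polar end on the same chain, such as a carboxylic acid or an amine, stays level with compound 2 or moves the read-out as the alkyne does.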